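Adding a methyl to the aromatic nitrogen of compound 1

The source may hold more compounds than are shown below. What is called first, only, known or untested is meant among the compounds shown, and "the series" means these compounds.

- compound 1 `COc1ccc(-c2cc3c(cn2)[nH]c(=O)n3-c2cc(OC)c(OC)c(OC)c2)cc1O` gives 240 nM
- compound 2 `COc1ccc(-c2cc3c(cn2)[nH]c(=O)n3-c2cc(OC)c(OC)c(OC)c2)cn1` gives 990 nM
- compound 3 `COc1ccc(-c2cc3c(cn2)[nH]c(=O)n3-c2cc(OC)c(OC)c(OC)c2)cc1N` gives 640 nM

These values come from a functional assay on A2780 cells (Homo sapiens) for antiproliferative activity, read by MTT assay, with a stated time of 48 h (on this read-out higher numbers stand for weaker inhibition and lower numbers for stronger inhibition), where compound 1 has the lowest number of the three. The modest steps away from it are a 2.7-fold higher number from compound 1 to compound 3 (0.43 log units; beyond the scatter) and a 4.1-fold higher number from compound 1 to compound 2 (0.62 log units; beyond the scatter), both beyond the scatter, while a 1.5-fold lower number from compound 2 to compound 3 (0.19 log units; within the scatter) stays within it.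

Compound 4 `COc1ccc(-c2cc3c(cn2)n(C)c(=O)n3-c2cc(OC)c(OC)c(OC)c2)cc1O` carries one change from compound 1: methyl in place of hydrogen on an aromatic nitrogen. For the measured compounds named here, no measured step touches that nitrogen, so those steps offer only a rough guide to size and none to direction. No step beyond the scatter is therefore expected, though the uncertainty is wide. The expected change is a 1.2-fold lower number from compound 1 to compound 4 (0.08 log units; within the scatter). The estimate for compound 4 is 200 nM, within an expected range of 60 nM to 700 nM.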

Compound 4, half-maximal inhibitory concentration: 1720 nM
Beside the measured number, compound 4's estimate is 8.6-fold (0.93 log units) below it; the measured number lies above the stated range.
By their numbers in this assay, from the lowest: compound 1; then compounds 3, 2 and 4 (each within the scatter of the next, the first and the last beyond it).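

In this assay, methyl in place of hydrogen on the aromatic nitrogen gives a 7.2-fold higher number from compound 1 to compound 4 (0.86 log units; beyond the scatter) and moves compound 1 out of its place at the low end of the series. The earlier compounds all keep this hydrogen, so only now is this nitrogen shown to be sensitive, even to a single added carbon. No measurement here accounts for the loss.

The compounds shown do not separate the loss of the hydrogen from the presence of the methyl. Going by these compounds, how an ethyl group or a longer chain on this nitrogen would compare also remains open.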